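A Pyrrolidinyl Urea Variant of Compound 2

The source may hold more compounds than are shown below. What is called first, only, known or untested is meant among the compounds shown, and "the series" means these compounds.

Of the compounds shown here, three built on one shared core have been measured in a functional assay on HEK293 cells for agonist activity at Vasopressin V2 receptor (Homo sapiens), read by a luciferase reporter and cAMP accumulation; on this read-out higher numbers stand for an effect only at larger amounts of compound and lower numbers for an effect already at smaller amounts. Compound 1 `Cc1cc(C(=O)N2CCCCc3ccccc32)cc(C)c1CNC(=O)Nc1c(F)cccc1F` gives 82 nM. Compound 2 `Cc1cc(C(=O)N2CCCCc3ccccc32)ccc1CNC(=O)NCC(=O)N1CCCC1` gives 100 nM, the highest of the three numbers; its nearest neighbour is compound 1, and the two values lie within the scatter of each other. Compound 3 `CCO[C@@H]1C[C@@H](C(=O)N(C)C)N(C(=O)NCc2ccc(C(=O)N3CCCCc4ccccc43)cc2C)C1` gives 4.3 nM, and the gap between compound 3 and compound 2 lies beyond the scatter, so compound 3 stands as the lowest of the three.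

Compound 4 `Cc1cc(C(=O)N2CCCCc3ccccc32)ccc1CNC(=O)N1CC(=O)C[C@H]1C(=O)N(C)C` has not yet been measured. It differs from compound 2 in one place: 2-(dimethylcarbamoyl)-4-oxopyrrolidin-1-yl in place of (((pyrrolidin-1-yl)carbonyl)methyl)amino on a carbonyl carbon. Among the measured compounds shown here, no step between measured compounds that differ in one place is available, so the change is judged against the whole set. Compound 3 carries a related pyrrolidinyl urea bearing a dimethylcarbamoyl group, and it is the closest guide to what the new arrangement may do. For compound 4 a lower number than for compound 2 is expected, with a step beyond the scatter, estimated as a 6.7-fold lower number from compound 2 to compound 4 (0.82 log units; beyond the scatter). The expected value for compound 4 is 15 nM, with a range from 4 nM to 60 nM, because compound 3 gives 4.3 nM with a similar urea arrangement.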

Compound 4, half-maximal effective concentration: 27 nM
Beside the measured number, compound 4's estimate is 1.8-fold (0.26 log units) below it; the range from low to high includes it.
By their numbers in this assay, from the lowest: compound 3; then compound 4; then compounds 1 and 2 (each within the scatter of the next).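

Among the compounds shown here, the first one-place step at this position, on a carbonyl carbon whose other neighbours are an amide-type nitrogen, shows that the (((pyrrolidin-1-yl)carbonyl)methyl)amino group can give way to 2-(dimethylcarbamoyl)-4-oxopyrrolidin-1-yl without loss of agonist effect: in this assay the exchange gives a 3.7-fold lower number from compound 2 to compound 4 (0.57 log units; beyond the scatter). The position therefore accepts a group with 0 hydrogen-bond donors in place of one with 1, and with the pyrrolidine ring now bound directly to the carbonyl carbon through its nitrogen rather than held at the end of a chain, and the number still moves in the favourable direction, though the step is modest. Nothing in the data shown accounts for this step.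

The exchange alters the donor count, the ring attachment, the added carbonyl, the dimethylcarbamoyl group and the defined stereocentre all at once, so the compounds shown cannot assign the step to any one of these features. As far as these compounds go, it remains open how the number would respond to an unsubstituted pyrrolidin-1-yl at this place, to a carboxylic acid in place of the dimethylcarbamoyl group, or to the opposite configuration at the stereocentre.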